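The compounds below may be only part of what the source reports. "The series", "measured", "known", "first", "only" and "open" are said of these compounds alone.

Going by the values given here, compound 1 (`COc1cccc(C(=O)c2ccc3c(ccn3S(=O)(=O)c3cccc(/C=C/C(=O)NO)c3)c2)c1`) is the only compound with a numerical result in an assay on isolated protein for inhibition of polyamine deacetylase HDAC10 (Homo sapiens); on this read-out lower numbers stand for stronger inhibition and higher numbers for weaker inhibition; in this assay compound 1 gives 7740 nM. Compound 2 (`O=C(NO)c1ccc(Cn2ccc3cc(C(=O)c4ccc(Cl)cc4)ccc32)cc1`) reaches only a limit of the assay, as in this assay compound 2 gives > 100000 nM, the same limit described by the limit of > 100000 nM in this assay, at which 1 of the 2 values shown sits. Compound 3 (`COc1ccc(C(=O)c2ccc3c(ccn3S(=O)(=O)c3cccc(/C=C/C(=O)NO)c3)c2)cc1`) differs from compound 1 by 4-methoxyphenyl in place of 3-methoxyphenyl on a carbonyl carbon. Among the compounds with values here, no measured pair isolates such a change, so the expected step from compound 1 to compound 3 is small, within the usual scatter, with no clear direction: a 1.0-fold lower number from compound 1 to compound 3 (0.01 log units; within the scatter). Compound 3 is therefore estimated at 7500 nM, in a range from 2500 nM to 22000 nM.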

Compound 3, half-maximal inhibitory concentration: 5890 nM
Beside the measured number, compound 3's estimate is 1.3-fold (0.10 log units) above it; the measured number falls inside the stated range.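

In this assay, going by these compounds alone, 4-methoxyphenyl in place of 3-methoxyphenyl on a carbonyl carbon gives the first step that can be read, a 1.3-fold lower number from compound 1 to compound 3 (0.12 log units; within the scatter). The two groups therefore cannot be told apart at this position, and the shared core tolerates this exchange without a change beyond the scatter. None of the data shown bears on a cause for this result. As far as these compounds go, what remains open is whether a larger change here, such as an amine or a carboxylic acid in place of the methoxy group, would move the number beyond the scatter.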